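Methyl for Fluoro at the Detection Limit

The source may hold more compounds than are shown below. What is called first, only, known or untested is meant among the compounds shown, and "the series" means these compounds.

Compound 1, `Cc1ccc(S(=O)(=O)Nc2ccc(-c3nc4ccccc4o3)cc2)cc1`, in an assay on isolated protein for inhibition of malate dehydrogenase, mitochondrial (Sus scrofa), with stated times of 45 min and 30 min; on this read-out higher numbers stand for weaker inhibition and lower numbers for stronger inhibition: compound 1 gives a limit, > 63000 nM.
Compound 2, `O=S(=O)(Nc1ccc(-c2nc3ccccc3o2)cc1)c1ccccc1F`: compound 2 gives a limit, > 63000 nM.
Compound 3, `O=S(=O)(Nc1ccc2oc(-c3ccccc3)nc2c1)c1cccc(O)c1`: compound 3 gives a limit, > 63000 nM.

Compound 2 thus stands at the limit of the assay, as do the other two compounds, which is what the limit of > 63000 nM in this assay, at which 3 of the 3 values shown sit, records. Going by the values given here, the only step between measured compounds, a step that the two limits leave unreadable from compound 1 to compound 2, cannot be read for that reason. Compound 4, `Cc1ccccc1S(=O)(=O)Nc1ccc(-c2nc3ccccc3o2)cc1`, differs from compound 2 by methyl in place of fluoro on an aromatic carbon. Among the compounds with values here, no measured step bears on this change, and no step in this assay can be expected to show beyond the scatter when both ends sit at the limit. Compound 4 is expected to stay at the limit, a step that the limit leaves unreadable from compound 2 to compound 4. Compound 4 is estimated at 100000 nM, with a range from 30000 nM to 400000 nM.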

Compound 4, half-maximal inhibitory concentration: > 63000 nM
Compound 4 was reported as a limit (the forecaster's own chance of this, stated with the estimate: 85%); the middle value is on the limit's open side.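

The steps reaching compound 4 from compound 1 and from compound 2 cannot be read, because compound 4 also gives only a limit: the limit of > 63000 nM in this assay, at which 4 of the 4 values shown sit.

The compounds shown leave open how strongly any of them acts in this assay, and whether 2-fluorophenyl and 2-methylphenyl differ at all.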